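Benzamide dithiocarbamates: methyl on the terminal phenyl

The source may report more compounds than this note shows. Statements on the series, on what has been measured and on what is new or still open speak of the compounds shown alone.

The series shares a benzamide dithiocarbamate core and differs in the amine attached to the thiocarbonyl carbon. Compound 1 `Nc1ccccc1NC(=O)c1ccc(CSC(=S)N2CCN(c3ccccc3)CC2)cc1` carries a phenylpiperazine. In a functional assay on A-375 cells (Homo sapiens) for antiproliferative activity, read by CCK-8 assay, with a stated time of 72 h, tested at 8 uM (on this read-out higher numbers stand for a stronger effect at the one concentration tested and lower numbers for a weaker effect), compound 1 gives 88.6%. Compound 2 `CC1CCCCN1C(=S)SCc1ccc(C(=O)Nc2ccccc2N)cc1`, with a 2-methylpiperidin-1-yl group, gives 85.2% in this assay, and compound 3 `CC1CCN(C(=S)SCc2ccc(C(=O)Nc3ccccc3N)cc2)CC1`, with a 4-methylpiperidin-1-yl group, gives 87.4%. All three numbers lie within the usual scatter of one another, so compound 1 sits level with compound 3 and compound 2 rather than apart from them.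

Among the compounds with values here, the only measured step, 4-methylpiperidin-1-yl in place of 2-methylpiperidin-1-yl on the thiocarbonyl carbon, reads a number 2.2 percentage points higher from compound 2 to compound 3 (within the scatter).

Compound 4 `Cc1ccc(N2CCN(C(=S)SCc3ccc(C(=O)Nc4ccccc4N)cc3)CC2)cc1` arises from compound 1 by the change (methyl in place of hydrogen on an aromatic carbon). Within the data shown here, no measured step touches that aromatic ring, and the one step on record concerns a different part of the molecule and stayed within the scatter. With no evidence of movement from any single methyl shift in this assay, the expectation for compound 4 is a step of a number 1.6 percentage points lower from compound 1 to compound 4 (within the scatter), that is, none beyond the scatter. Compound 4 is therefore estimated at 87% in this assay, with a range from 78% to 94%.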

Compound 4, a percentage reported as inhibition, at one concentration (the size of the read-out at that concentration, not a potency): 26.4%
Compound 4: the middle estimate sits 60.6 percentage points above what was measured; the whole stated range lies above it.
By their numbers in this assay, from the lowest: compound 4; then compounds 2, 3 and 1 (each within the scatter of the next).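

Within the data shown here, the terminal phenyl of compound 1 is sensitive in a way the earlier compounds gave no sign of. Phenyl to 4-methylphenyl, a single added carbon on an aromatic carbon para to a large group, gives a number 62.2 percentage points lower from compound 1 to compound 4 (beyond the scatter) in this assay, whereas moving a methyl on the piperidine, the only earlier comparison, gave a number 2.2 percentage points higher from compound 2 to compound 3 (within the scatter) and so showed no sensitivity there. The tolerance seen for that methyl therefore does not carry over to the terminal ring, and this one carbon is enough to separate compound 4 from compound 1 on this read-out. No measurement shown here accounts for the loss.

As far as these compounds go, whether the loss belongs to methyl itself or to any group on this carbon stays open, and a chlorine, a methoxy or an amine at the same place on the phenyl would help separate the two. From the compounds shown here alone, the read-out also stands at one concentration, so the change in potency between the two compounds remains unknown, as does the outcome of a methyl on another carbon of this ring.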